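The compounds below may be only part of what the source reports. "The series", "measured", "known", "first", "only" and "open" are said of these compounds alone.

Three compounds share the same core and were run in an ADME assay on HepG2 cells (Homo sapiens) for cytotoxicity, read by trypan blue exclusion, with a stated time of 48 h, in the presence of a further agent that is not named here; a lower number here means that less compound is tolerated, a higher number that more compound is tolerated. Compound 1 `COc1ccc2nc(C)cc(OCC(=O)Nc3ccccc3)c2c1` gives only a limit in this assay, > 155000 nM. Compound 2 `COc1ccc(NC(=O)COc2cc(C)nc3ccc(OC)cc23)cc1` likewise gives only a limit, > 142000 nM. Compound 3 `COc1ccc2nc(C)cc(OCC(=O)Nc3ccc(Br)cc3)c2c1` also reaches only a limit, > 125000 nM. Compound 3 thus stands among values that are all limits, and no order among the three can be drawn. The steps a step that the two limits leave unreadable from compound 1 to compound 2, a step that the two limits leave unreadable from compound 1 to compound 3 and a step that the two limits leave unreadable from compound 2 to compound 3 are unreadable in size for this reason. Compound 4 `COc1ccc2nc(C)cc(OCC(=O)Nc3ccccc3Cl)c2c1` differs from compound 3 by 2-chlorophenyl in place of 4-bromophenyl on an amide-type nitrogen. Within the data shown here, none of the measured steps gives a readable size that bears on this change. The step that the limit leaves unreadable from compound 3 to compound 4 is therefore expected to be none beyond the scatter. Compound 4 is expected to sit at 150000 nM, between 60000 nM and 400000 nM, most likely again as a limit.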

Compound 4, half-maximal cytotoxic concentration: > 140000 nM
Compound 4: no number, only a limit (the forecaster's own chance of this, stated with the estimate: 85%); the middle value is on the limit's open side.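

Among these compounds, compound 4, like compound 1, compound 2 and compound 3, gives only a limit in this assay, and no step to compound 4 from any of them can be read. The compounds shown leave open at what concentration any of the four becomes cytotoxic, and whether the groups on the phenyl ring change it.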